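The compounds below may be only part of what the source reports. "The series", "measured", "known", "first", "only" and "open" are said of these compounds alone.

Measured so far in a physicochemical assay for lipophilicity, using the shake flask method, in phosphate buffer, measured as octanol-water partition, with a stated time of 24 h, at pH 7.4, tested at 100 uM; a lower number here means a more polar compound, a higher number a more lipophilic compound:

- compound 1 `COc1cc(C)c(-c2cccc(COc3ccc(S(=O)(=O)CC(=O)O)cc3)c2)c(C)c1` – 2.45
- compound 2 `N#Cc1ccccc1-c1cccc(COc2ccc(S(=O)(=O)CC(=O)O)cc2)c1` – "not determined" (no result reported)

Compound 2 has no single number, so it offers no starting value. The change is 2-chloro-4-methylphenyl in place of 2-cyanophenyl on an aromatic carbon, with 2-chloro-4-methylphenyl in place of 2-cyanophenyl on an aromatic carbon. The resulting compound 3 has the structure `Cc1ccc(-c2cccc(COc3ccc(S(=O)(=O)CC(=O)O)cc3)c2)c(Cl)c1` and is still unmeasured. In this assay a clear upward step is expected, but its size can only be judged loosely. The nearest guide is compound 1 at 2.45 (a different compound, not a starting point). For compound 3 the estimated value is 2.5, with an expected range from 2 to 3 (an estimate, not a measurement).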

Compound 3, distribution coefficient: 3.05
Estimate against measurement, compound 3: 0.55 log units below, and the stated range ends below it.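

In this assay the swap of 4-methoxy-2,6-dimethylphenyl for 2-chloro-4-methylphenyl gives a number 0.60 log units higher from compound 1 to compound 3 (beyond the scatter) and so shows that the group on this aromatic carbon can shift the distribution coefficient beyond the usual scatter. Compound 2 has no number, so the change from 2-cyanophenyl cannot be read. Nothing given here accounts for the rise.

The compounds shown do not separate the share of the chlorine from that of the methyl in compound 3. From the compounds shown here alone, how an amine on this ring would compare also stays open.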